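The source may hold more compounds than are shown below. What is called first, only, known or untested is meant among the compounds shown, and "the series" means these compounds.

Measured so far in a functional assay on CHO cells for antagonist activity at prostaglandin E2 receptor EP3 subtype (Homo sapiens), read by cAMP accumulation; on this read-out higher numbers stand for weaker inhibition and lower numbers for stronger inhibition:
- compound 1, `CC(C)C(O)(C(=O)O)c1ccc(-c2ccc3ccccc3c2)[nH]c1=O`, gives 1580 nM
- compound 2, `Cc1nc(C(c2ccc(-c3ccc4cccc(F)c4c3)[nH]c2=O)C(C)C)[nH]c1C`, gives 50 nM
- compound 3, `CCn1ncc2c(F)cc(-c3ccc(C(CC)(CC)c4ncn(C)n4)c(=O)[nH]3)cc21`, gives 96 nM

Of these three numbers compound 2 carries the lowest one. Compound 3 sits closest to it, and the gap between them lies within the usual scatter of this assay, so the two cannot be ranked against each other. Compound 1 stands furthest away, beyond the scatter, with a clearly higher number than compound 2.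

Compound 4, `CC(C)NC(=O)CC(c1ccc(-c2ccc3cccc(F)c3c2)[nH]c1=O)C(C)C`, has not yet been measured in this assay. It differs from compound 2 in one place: (isopropylcarbamoyl)methyl in place of 4,5-dimethyl-1H-imidazol-2-yl on a saturated chain carbon bound to an aromatic carbon and a saturated chain carbon. Both groups carry the same count of heavy atoms and the same single hydrogen-bond donor and acceptor, but the five-membered aromatic ring with two hetero atoms is given up for a chain with one double bond outside aromatic rings.

Within the data shown here, no measured pair among the three compounds shows what such a swap does in this assay. On that footing the step is expected to be a moderate loss, somewhat beyond the scatter, rather than no change, and the expected step is a 3.0-fold higher number from compound 2 to compound 4 (0.48 log units; beyond the scatter). Compound 4 is accordingly estimated at 150 nM, with a range from 40 nM to 600 nM.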

Compound 4, half-maximal inhibitory concentration: 15 nM
Compound 4: the middle estimate sits 10-fold (1.00 log units) above what was measured; the whole stated range lies above it.
By their numbers in this assay, from the lowest: compound 4; then compounds 2 and 3 (each within the scatter of the next); then compound 1.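

In this assay, the saturated chain carbon bound to an aromatic carbon and a saturated chain carbon does not depend on keeping 4,5-dimethyl-1H-imidazol-2-yl: replacing it with (isopropylcarbamoyl)methyl gives a 3.3-fold lower number from compound 2 to compound 4 (0.52 log units; beyond the scatter). This only pair differing in one place shows that a chain with no ring and one double bond outside aromatic rings can stand here, while the heavy-atom, donor and acceptor counts stay the same, so those counts alone do not account for the step. No measurement on hand explains why the number falls with this change.

This single pair cannot separate the part played by the isopropyl group from that of the carbamoyl group or the loss of the ring. From the compounds shown here alone, whether a primary amide, a tert-butyl amide or a methyl ester at this place would give a similar number remains open.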